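The source may hold more compounds than are shown below. What is called first, only, known or untested is meant among the compounds shown, and "the series" means these compounds.

Compound 2 `CC(C)[C@@H]1CC[C@@H](C)C[C@@]12N(C)C(=O)[C@@H]1[C@H]3C(=O)N(c4ccc(Cl)cc4)C(=O)[C@H]3ON12` gives the lowest of the two numbers in a functional assay, read by spectrophotometry, with a stated time of 2 h (on this read-out lower numbers stand for stronger inhibition and higher numbers for weaker inhibition), at 710 ug/mL. Compound 3 `Cc1cccc(N2C(=O)[C@H]3[C@H](ON4[C@@H]3C(=O)N(C)[C@@]43C[C@H](C)CC[C@H]3C(C)C)C2=O)c1` gives 1930 ug/mL; for compound 1 `CC(C)[C@@H]1CC[C@@H](C)C[C@@]12N(C)C(=O)[C@@H]1[C@H]3C(=O)NC(=O)[C@H]3ON12` the entry reads "not determined" (no result reported). Compound 4 `Cc1ccc(N2C(=O)[C@H]3[C@H](ON4[C@@H]3C(=O)N(C)[C@@]43C[C@H](C)CC[C@H]3C(C)C)C2=O)c(C)c1` differs from compound 2 by 2,4-dimethylphenyl in place of 4-chlorophenyl on an amide-type nitrogen in a ring. Among the measured compounds shown here, the only measured step that bears on this change is a 2.7-fold higher number from compound 2 to compound 3 (0.43 log units; beyond the scatter), in which an aryl group carrying one methyl replaced the chlorinated aryl. Because that step read a 2.7-fold higher number from compound 2 to compound 3 (0.43 log units; beyond the scatter), the dimethylated aryl of compound 4 is expected to move in the same direction, a modest rise in this assay, shown as a 2.1-fold higher number from compound 2 to compound 4 (0.32 log units; beyond the scatter). Compound 4 is therefore estimated at 1500 ug/mL, with a range from 600 ug/mL to 4000 ug/mL.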

Compound 4, half-maximal inhibitory concentration: 430 ug/mL
Compound 4: the middle estimate sits 3.5-fold (0.54 log units) above what was measured; measured number below the stated range.
By their numbers in this assay, from the lowest: compounds 4 and 2 (each within the scatter of the next); then compound 3.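

In this assay, the change to 2,4-dimethylphenyl on the amide-type nitrogen gives a 1.7-fold lower number from compound 2 to compound 4 (0.22 log units; within the scatter), so this methylated aryl does not share the rise seen with 3-methylphenyl. The two methylated aryl groups differ clearly, with a 4.5-fold lower number from compound 3 to compound 4 (0.65 log units; beyond the scatter), which shows that the methyl pattern on this aryl group matters to the number, not simply the presence of methyl. No measurement offered here explains this difference. On these data alone, whether an aryl group carrying an amine or a carboxylic acid would read like these remains open, as does a longer alkyl chain on this nitrogen.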